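Chloro for fluoro on the fused ring: series notes

The compounds below may be only part of what the source reports. "The series", "measured", "known", "first", "only" and "open" are said of these compounds alone.

Measured so far:
compound 1 `Fc1ccc2[nH]c(-c3cn(-c4ccccc4)nc3-c3ccccc3)nc2c1` — 1720 nM
compound 2 `Clc1ccc2[nH]c(-c3cn(-c4ccccc4)nc3-c3ccccc3)nc2c1` — 2370 nM
compound 3 `Fc1ccc(-c2nn(-c3ccccc3)cc2-c2nc3cc(F)ccc3[nH]2)cc1` — 1130 nM

All three numbers come from a functional assay on A549 cells (Homo sapiens) for antiproliferative activity, read by MTT assay, with a stated time of 48 h; a higher number here means a weaker inhibitor, a lower number a stronger inhibitor. Compound 1 and compound 3 share a core up to one difference, (fluoro in place of hydrogen on an aromatic carbon); the step across that difference is a 1.5-fold lower number from compound 1 to compound 3 (0.18 log units; within the scatter). Compound 2 carries the core of compound 1 with one change, (chloro in place of fluoro on an aromatic carbon), and the step is a 1.4-fold higher number from compound 1 to compound 2 (0.14 log units; within the scatter).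

Compound 4 `Fc1ccc(-c2nn(-c3ccccc3)cc2-c2nc3cc(Cl)ccc3[nH]2)cc1` has not been run in this assay. It stands to compound 3 as compound 2 stands to compound 1: chloro in place of fluoro on an aromatic carbon. The description of the place is the same word for word in both pairs, so this is the same change rather than merely the same kind.

No number is known for compound 4 yet. The estimate rests on one precedent only, because the same change gave a 1.4-fold higher number from compound 1 to compound 2 (0.14 log units; within the scatter) within the scatter. The expected step is a 1.4-fold higher number from compound 3 to compound 4 (0.14 log units; within the scatter), set beside the earlier one. Compound 4 is therefore expected to give about 1550 nM in this assay.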

Compound 4, half-maximal inhibitory concentration: 1320 nM
Compound 4: the middle estimate sits 1.2-fold (0.07 log units) above what was measured; the measured number falls inside the stated range.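

In this assay, chloro in place of fluoro on an aromatic carbon gives a 1.2-fold higher number from compound 3 to compound 4 (0.07 log units; within the scatter), and this step agrees with the one on the core of compound 1: the same change on two cores in this assay, a 1.4-fold higher number (0.14 log units; within the scatter) from compound 1 to compound 2 and a 1.2-fold higher number (0.07 log units; within the scatter) from compound 3 to compound 4, 1.2-fold (0.07 log units) apart, within the scatter of two such steps

Fluoro in place of hydrogen on an aromatic carbon also carries across the two cores, giving a 1.8-fold lower number from compound 2 to compound 4 (0.25 log units; within the scatter) on the chloro-bearing core: the same change on two cores in this assay, a 1.5-fold lower number (0.18 log units; within the scatter) from compound 1 to compound 3 and a 1.8-fold lower number (0.25 log units; within the scatter) from compound 2 to compound 4, 1.2-fold (0.07 log units) apart, within the scatter of two such steps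

Among the compounds shown here, since every one of these steps lies within the scatter, the two pairs show only that neither change moved the number measurably on these two cores; they fix no direction or size for either change and establish no rule for the wider series.

The compounds shown carry only hydrogen, fluoro or chloro in the two places varied, so it remains open whether a methoxy group, an amine or a carboxylic acid there would move the number beyond the scatter. From the compounds shown here alone, whether these small steps would also hold on a core differing elsewhere also remains open.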